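Chloro for methyl on a shared core

This account rests on a few compounds, and the source may have more. Where it says the series, first, only, none or still open, it means among the compounds named here.

Measured so far:
Compound 1 `Cc1ccc(-c2cc(C(=O)N3CCC4(CC3)CC(=O)c3nn(C(C)(C)C)cc3O4)c3ccccc3n2)cc1`: 1440 nM
Compound 2 `Cc1cc(C(=O)N2CCC3(CC2)CC(=O)c2nn(C(C)(C)C)cc2O3)c2ccccc2n1`: 9480 nM

Among the measured compounds shown here, in a functional assay on HepG2 cells (Homo sapiens) for inhibition, read by MTT assay, with a stated time of 72 h (on this read-out lower numbers stand for stronger inhibition and higher numbers for weaker inhibition), compound 2 gives 9480 nM, the higher of the two numbers, and its only neighbour, compound 1, gives 1440 nM. The next compound, compound 3 `CC(C)(C)n1cc2c(n1)C(=O)CC1(CCN(C(=O)c3cc(Cl)nc4ccccc34)CC1)O2`, keeps the core of compound 2 and changes a single group: chloro in place of methyl on an aromatic carbon. This places chloro in place of methyl on an aromatic carbon, next to the ring nitrogen.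

For the measured compounds named here, one measured step bears on this carbon: a 6.6-fold higher number from compound 1 to compound 2 (0.82 log units; beyond the scatter), with methyl in place of 4-methylphenyl. That step was modest, though beyond the scatter, and it exchanged a far larger group than the present swap does. A smaller step is therefore expected in this assay, possibly none beyond the scatter, and the data give no firm direction for it. The expected change is a 1.2-fold lower number from compound 2 to compound 3 (0.07 log units; within the scatter). For compound 3 the estimated value is 8000 nM, with an expected range from 3200 nM to 18000 nM.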

Compound 3, half-maximal inhibitory concentration: 4720 nM
Estimate against measurement, compound 3: 1.7-fold (0.23 log units) above, within the range that was stated.
By their numbers in this assay, from the lowest: compound 1; then compounds 3 and 2 (each within the scatter of the next).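

In this assay the swap at this carbon gives a 2.0-fold lower number from compound 2 to compound 3 (0.30 log units; within the scatter) and so stays within the scatter, which means chloro and methyl, each a single heavy atom, cannot be told apart on this core. The other new comparison, a 3.3-fold higher number from compound 1 to compound 3 (0.52 log units; beyond the scatter), lies beyond the scatter and, although modest, shows that compound 1 with its 4-methylphenyl group stands apart from compound 3 as well as from compound 2, so among these three compounds the two with a one-atom group fall together and compound 1 is the only one set apart. No measurement offered here accounts for these numbers, so the grouping remains a description and carries no explanation.

Going by these compounds, whether a plain phenyl, a methoxy or an amine on this carbon would fall with compound 1 or with the pair of compound 2 and compound 3 remains open. Also open, on these data alone, is whether the same grouping would hold if the tert-butyl group or another part of the shared core were replaced.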